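The source may hold more compounds than are shown below. What is called first, only, known or untested is meant among the compounds shown, and "the series" means these compounds.

Measured in a functional assay on HeLa cells (Homo sapiens) for cytotoxicity, read by WST assay, with a stated time of 48 h; on this read-out lower numbers stand for stronger inhibition and higher numbers for weaker inhibition:
- compound 1 `COc1cc(C(c2ccc(O)c(OC)c2)[C@@H](C)[C@@H](C)CO)ccc1O`: > 100000 nM (a limit of the assay, not a number)
- compound 2 `COc1cc(C(c2ccc(O)c(OC)c2)[C@@H](C)[C@@H](C)CF)ccc1O`: 42000 nM
- compound 3 `COc1cc(C(c2ccc(O)c(OC)c2)[C@@H](C)C(C)C)ccc1O`: 19000 nM

Compound 3, at 19000 nM, has the lowest number of the three. Its nearest neighbour is compound 2 at 42000 nM.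

The next compound is compound 4 `COc1cc(C(c2ccc(O)c(OC)c2)[C@@H](C)[C@H](C)CO)ccc1O`. Going to it from compound 3 is a single change: hydroxy in place of hydrogen on a saturated chain carbon, four bonds along the chain from two aromatic carbons.

The closest measured evidence is the same exchange run the other way, an at least 5.2-fold lower number from compound 1 to compound 3 (0.72 log units; beyond the scatter). Two further steps at that carbon point the same way, an at least 2.3-fold lower number from compound 1 to compound 2 (0.37 log units; beyond the scatter) and a 2.2-fold lower number from compound 2 to compound 3 (0.34 log units; beyond the scatter). In each of them, the number falls as the hydroxy or fluoro gives way.

A clear rise in the number is therefore expected in this assay, beyond the scatter. The expected size is a 4.7-fold higher number from compound 3 to compound 4 (0.68 log units; beyond the scatter). A report as a limit alone is about as likely as a number, and the range is kept wide. Compound 4 is estimated at 90000 nM, with an expected range of 35000 nM to 200000 nM.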

Compound 4, half-maximal inhibitory concentration: > 100000 nM
Compound 4 ended at the assay's limit; the forecaster's own chance of this, stated with the estimate: 50%; middle value at least 1.1-fold (0.04 log units) from the limit.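

In this assay, hydroxy in place of hydrogen on this saturated chain carbon gives an at least 5.2-fold higher number from compound 3 to compound 4 (0.72 log units; beyond the scatter), and 1-(hydroxymethyl)ethyl in place of 1-(fluoromethyl)ethyl gives an at least 2.3-fold higher number from compound 2 to compound 4 (0.37 log units; beyond the scatter). The hydroxy compounds now cover both drawn configurations at one stereocentre, and neither gives a readable number, so the rise seen on adding hydroxy is not confined to a single configuration: the fact that compounds 1 and 4 differ only in the configuration as drawn. The step between these two compounds cannot be read, and any effect of configuration on the hydroxy series stays hidden: the limit of > 100000 nM in this assay, at which 2 of the 4 values shown sit.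

Going by these compounds, whether an amine, a carboxylic acid or a methoxy at this chain end would behave like the hydroxy, the fluoro or the hydrogen remains open. Also open, on these data alone, is whether the fluoro compound would respond to the opposite configuration at this stereocentre, which could be read only from a number inside the range of this assay.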